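Motilin receptor macrocycles: acid side chain to hydroxyl

The source may report more compounds than this note shows. Statements on the series, on what has been measured and on what is new or still open speak of the compounds shown alone.

Compound 1, `CCC[C@@H]1NC(=O)[C@@H](C(C)C)NC(=O)[C@@H](CCCCN)NCCOc2ccccc2/C=C/CNC1=O`: in an assay on isolated protein for displacement of a labelled ligand from Motilin receptor (Homo sapiens) (on this read-out higher numbers stand for weaker inhibition and lower numbers for stronger inhibition), compound 1 gives > 10000 nM, a limit of the assay and not a number.
Compound 2, `CCC[C@@H]1NC(=O)[C@@H](CCC(=O)O)NC(=O)[C@@H](Cc2ccc(O)cc2)NCCOc2ccccc2/C=C/CNC1=O`: in this assay compound 2 gives 4900 nM.

The limit recorded for compound 1 is the limit of > 10000 nM in this assay, at which 1 of the 2 values shown sits. For the measured compounds named here, compound 2 therefore stands as the only measured number so far. Compound 3, `CCC[C@@H]1NC(=O)[C@@H](CO)NC(=O)[C@@H](Cc2ccc(O)cc2)NCCOc2ccccc2/C=C/CNC1=O`, differs from compound 2 by hydroxy in place of carboxymethyl on a saturated chain carbon bound to a saturated ring carbon. Going by the values given here, no measured step covers such a change here, so the step of a 1.0-fold higher number from compound 2 to compound 3 (0.01 log units; within the scatter) is expected to stay within the usual scatter, with no set direction. On that basis compound 3 is estimated at 5000 nM, with a range from 1500 nM to 15000 nM.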

Compound 3, inhibition constant: > 10000 nM
Compound 3 gave a limit, no number (the forecaster's own chance of this, stated with the estimate: 35%); at least 2.0-fold (0.30 log units) between middle value and limit.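

The change from carboxymethyl to hydroxy, on a saturated chain carbon bound to a saturated ring carbon, gives the first step read at this position in this assay: an at least 2.0-fold higher number from compound 2 to compound 3 (0.30 log units; that floor lies within the scatter). The floor of that step lies within the scatter, so no real loss can be claimed from it. Compound 3 stands at a limit of the assay and not at a number: the limit of > 10000 nM in this assay, at which 2 of the 3 values shown sit.

On these data alone, how far compound 3 lies past its limit remains open. Also open, as far as these compounds go, is whether a primary amide, or a longer chain ending in a carboxylic acid, would give a number at this position.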